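A few compounds are considered here, and "the series" means these few. Any claim that something is new, unique, unknown or untested is made for them only; others in the source may bear on it.

Of the compounds shown here, three from this set have been measured in a functional assay; on this read-out lower numbers stand for stronger inhibition and higher numbers for weaker inhibition. Compound 1, `CC(C)=CCOc1ccc2c(c1)OC(c1ccc(F)cc1)CC2=O`, gives 7320 nM. Compound 2, `COc1ccc(C2CC(=O)c3ccc(OCC=C(C)C)cc3O2)c(OC)c1`, gives 8180 nM. Compound 3, `CC(C)=CCOc1cc(O)c2c(c1)OC(c1ccc(F)cc1)CC2=O`, gives 6060 nM, the lowest of the three numbers, although its gaps to compound 1 and to compound 2 both lie within the scatter, so no order among the three can be claimed.

Within the data shown here, the one single-point step so far is a 1.2-fold lower number from compound 1 to compound 3 (0.08 log units; within the scatter), a change that left the number essentially where it was.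

The next compound, compound 4, `CC(C)=CCOc1cc(O)c2c(c1)OC(c1ccc(O)cc1)CC2=O`, differs from compound 3 in this way: hydroxy in place of fluoro on an aromatic carbon. Among the measured compounds shown here, no measured pair shows this exchange, and the only step recorded, hydroxy for hydrogen elsewhere on the shared core, stayed within the scatter. The values of compounds 1 and 2, which carry different aryl groups, also sit within the scatter of each other. The data therefore give no ground to expect a move beyond the scatter in this assay, and the expected step of a 1.1-fold lower number from compound 3 to compound 4 (0.04 log units; within the scatter) is correspondingly small. Compound 4 is thus estimated at 5500 nM, with a range from 2000 nM to 15000 nM.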

Compound 4, half-maximal inhibitory concentration: 5340 nM
Beside the measured number, compound 4's estimate is 1.0-fold (0.01 log units) above it; measured number inside the range.
By their numbers in this assay, from the lowest: compounds 4, 3, 1 and 2 (each within the scatter of the next).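

Exchanging fluoro for hydroxy on the aromatic carbon para to a large group, the first change seen at this position, gives a 1.1-fold lower number from compound 3 to compound 4 (0.05 log units; within the scatter) in this assay. The 4-hydroxyphenyl group carries a hydrogen-bond donor and a hydrogen-bond acceptor that the 4-fluorophenyl group lacks, yet this exchange stays within the scatter, as does the earlier hydroxy-for-hydrogen step on the shared core, a 1.2-fold lower number from compound 1 to compound 3 (0.08 log units; within the scatter), so neither of the two hydroxy changes shown separates its pair of compounds on this read-out. Nothing measured alongside these numbers offers an explanation for this result.

Fluoro and hydroxy are the only two groups compared at this position, both a single heavy atom, so it remains open whether a larger group such as a trifluoromethyl, an amine or a carboxylic acid would move the number beyond the scatter. No step shown so far lies beyond the scatter, which also leaves open whether any single change to the shared core can shift the number appreciably.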